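The source may hold more compounds than are shown below. What is called first, only, known or untested is meant among the compounds shown, and "the series" means these compounds.

Measured so far in a functional assay on the whole organism for inhibition, with Echinochloa esculenta as the target; on this read-out higher numbers stand for weaker inhibition and lower numbers for stronger inhibition:
- Compound 1 `S=c1n(-c2ccccc2)c(=S)n2n1CCCC2` gives 3550 nM
- Compound 2 `CC(C)Oc1cc(/N=c2\sc(=S)n3n2CCCC3)c(F)cc1Cl` gives 28.2 nM

Compound 2 holds the lower of the two numbers, beyond the scatter from compound 1. Compound 3 `Fc1cc(Cl)ccc1/N=c1\sc(=S)n2n1CCCC2` has hydrogen in place of isopropoxy on an aromatic carbon and has not yet been measured. For the measured compounds named here, no measured pair isolates this change. Compound 1 also has no isopropoxy and gives 3550 nM in this assay, although it differs from compound 2 elsewhere too. A rise beyond the scatter is therefore expected. The expected change is a 14-fold higher number from compound 2 to compound 3 (1.15 log units; beyond the scatter) towards weaker inhibition. The estimate for compound 3 is 400 nM within an expected range of 80 nM to 2000 nM overall.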

Compound 3, half-maximal inhibitory concentration: 158 nM
Beside the measured number, compound 3's estimate is 2.5-fold (0.40 log units) above it, within the range that was stated.
By their numbers in this assay, from the lowest: compound 2; then compound 3; then compound 1.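

For the compounds shown here, for the first time, a single change at this position can be read on its own: exchanging isopropoxy for hydrogen, with the rest of the molecule unchanged, gives a 5.6-fold higher number from compound 2 to compound 3 (0.75 log units; beyond the scatter) in this assay. Isopropoxy on this aromatic carbon therefore goes with stronger inhibition than hydrogen does, although the hydrogen analogue still keeps a measurable potency. Nothing available explains the size of this step. On these data alone, whether methoxy, a longer chain such as butoxy, or an amine at this position would give a lower or higher number remains open.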